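Methoxy for chloro on a fused ring: an expectation

The source may report more compounds than this note shows. Statements on the series, on what has been measured and on what is new or still open speak of the compounds shown alone.

Measured so far:
Compound 1, `COc1ccc(C2CC(c3ccc4ccccc4c3)=NN2C2=NC(=O)/C(=C3/C(=O)Nc4ccc(C)cc43)S2)cc1`, gives 100 nM in a functional assay on BXPC-3 cells (Homo sapiens) for antiproliferative activity, read by MTT assay, with a stated time of 72 h; a lower number here means that less compound is needed, a higher number that more compound is needed for the effect.
Compound 2, `COc1ccc(C2CC(c3ccc4ccccc4c3)=NN2C2=NC(=O)/C(=C3/C(=O)Nc4ccc(Cl)cc43)S2)cc1`, gives 60 nM in this assay.

Compound 2 has the lowest number of the two measured compounds, but its nearest neighbour, compound 1, is close: the step of a 1.7-fold lower number from compound 1 to compound 2 (0.22 log units; within the scatter) lies within the scatter, so the two cannot be ranked against each other.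

Compound 3, `COc1ccc(C2CC(c3ccc4ccccc4c3)=NN2C2=NC(=O)/C(=C3/C(=O)Nc4ccc(OC)cc43)S2)cc1`, has not yet been measured in this assay. It differs from compound 2 in one place: methoxy in place of chloro on an aromatic carbon.

Among the measured compounds shown here, only one measured step bears on this change, and it exchanged chloro for methyl at the same place: a 1.7-fold lower number from compound 1 to compound 2 (0.22 log units; within the scatter). That step stayed within the scatter, so a small group at this carbon appears to leave the number largely unchanged. Methoxy is another small group there, so no step beyond the scatter is expected in either direction.

For compound 3 the expected step is a 1.5-fold higher number from compound 2 to compound 3 (0.18 log units; within the scatter), and the estimated value is 90 nM, with a range from 40 nM to 200 nM.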

Compound 3, half-maximal effective concentration: 100 nM
Beside the measured number, compound 3's estimate is 1.1-fold (0.05 log units) below it; the range from low to high includes it.
By their numbers in this assay, from the lowest: compounds 2, 1 and 3 (each within the scatter of the next).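

In this assay the exchange of chloro for methoxy gives a 1.7-fold higher number from compound 2 to compound 3 (0.22 log units; within the scatter) and the exchange of methyl for methoxy gives no change at the digits printed from compound 1 to compound 3 (within the scatter) on the same aromatic carbon, so methoxy can now be compared directly with both earlier groups. This carbon has therefore carried chloro, methyl and methoxy, and none of the three can be ranked against the others in this assay, even though methoxy has two heavy atoms where chloro has one and adds a hydrogen-bond acceptor that chloro lacks. Nothing available here explains why these three compounds read alike.

As far as these compounds go, whether this carbon also tolerates quite different groups, such as an amine, a carboxylic acid or a longer chain, remains open, since all three groups seen so far are small and uncharged. It is also unknown whether the same holds at the other carbons of this ring or when the rest of the shared core is changed.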